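The compounds below may be only part of what the source reports. "The series", "measured", "known", "first", "only" and "open" are said of these compounds alone.

Within the data shown here, compound 2 `O=C(CN1CCC(c2cccc[n+]2[O-])CC1)Nc1cc(Cl)cc(Cl)c1` gives 160 nM in a functional assay on HEK293 cells for agonist activity at D(4) dopamine receptor (Homo sapiens), read by FLIPR (on this read-out higher numbers stand for an effect only at larger amounts of compound and lower numbers for an effect already at smaller amounts), and holds the lowest number of the two measured so far; compound 1 `O=C(NCN1CCC(c2cccc[n+]2[O-])CC1)c1ccccc1` gives 532 nM in this assay, a gap beyond the scatter. Compound 3 `Cc1cc(F)ccc1NC(=O)CN1CCC(c2cccc[n+]2[O-])CC1` carries 4-fluoro-2-methylphenyl in place of 3,5-dichlorophenyl on an amide-type nitrogen. Among the measured compounds shown here, with no measured pair covering this change, only a modest step is expected, if any, with a weak lean toward a higher number; the expected step from compound 2 to compound 3 is a 1.9-fold higher number from compound 2 to compound 3 (0.27 log units; within the scatter). Compound 3 is thus estimated at 300 nM in this assay, within a range from 100 nM to 900 nM.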

Compound 3, half-maximal effective concentration: 60 nM
Compound 3: middle estimate off by 5.0-fold (0.70 log units), on the high side; the whole stated range lies above it.
By their numbers in this assay, from the lowest: compound 3; then compound 2; then compound 1.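

Among these compounds, at this amide-type nitrogen, the 3,5-dichlorophenyl group is not required: 4-fluoro-2-methylphenyl gives a 2.7-fold lower number from compound 2 to compound 3 (0.43 log units; beyond the scatter) in this assay and sets the lowest number so far. Both groups have the same heavy-atom count and a six-membered aromatic ring of carbon only, so the step comes with a change of ring substituents alone. No available evidence bears on the reason for this step.

On these data alone, whether the step belongs to the fluorine, the methyl or the loss of the chlorines stays open, as all three change together. As far as these compounds go, how an unsubstituted phenyl or a pyridyl ring on the same nitrogen would read in this assay also stays open.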